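Glycolipid series: tolerated concentrations and the free acid

The source may hold more compounds than are shown below. What is called first, only, known or untested is meant among the compounds shown, and "the series" means these compounds.

The series is a set of glycosylated lipid amides read in a functional assay on MT4 cells (Homo sapiens) for cytotoxicity; a lower number here means that less compound is tolerated, a higher number that more compound is tolerated. Compound 1 `CCCCCCCCCCCCCCNC(=O)C(CO[C@@H]1O[C@H](CO)[C@H](O)[C@H](O)[C@H]1O)NC(=O)CCC(=O)NCCS(=O)(=O)O` returns only a limit there; in this assay compound 1 gives > 100000 nM, which is a limit of the assay and not a number. Compound 1 therefore sits at the limit of > 100000 nM in this assay, at which 1 of the 3 values shown sits, the upper end of what is shown. Among the measured compounds shown here, compound 2 `CCCCCCCCCCCCCC(=O)NCC(NC(=O)CCCCCCCCCCCCC)C(=O)NCCN(CCNC(=O)C(O)C(O)C(O[C@@H]1O[C@H](CO)[C@H](O)[C@H](O)C1O)C(O)CO)CCNC(=O)C(O)C(O)C(O[C@@H]1O[C@H](CO)[C@H](O)[C@H](O)[C@H]1O)C(O)CO` is the one member with a number: in this assay compound 2 gives 38000 nM. Compound 3 `O=C(O)CCCCCCCCCCC(=O)N(CCCCCCCC(F)(F)C(F)(F)C(F)(F)C(F)(F)C(F)(F)C(F)(F)C(F)(F)C(F)(F)F)CCO[C@@H]1O[C@H](CO)[C@H](O)[C@H](O)[C@H]1O` again returns only a limit; in this assay compound 3 gives > 18000 nM, a limit of the assay. For the measured compounds named here, no two measured compounds differ in a single place, so no measured step is available.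

Compound 4 `CCCCCCCCCCCCCCNC(=O)C(CO[C@@H]1O[C@H](CO)[C@H](O)[C@H](O)[C@H]1O)NC(=O)CCC(=O)O` is the one-place variant of compound 1. The change: hydroxy in place of (2-sulfoethyl)amino on a carbonyl carbon. Going by the values given here, with no measured step to lean on, the expectation for compound 4 rests on compound 1 alone. Since compound 1 already stands at the limit of > 100000 nM in this assay, at which 1 of the 3 values shown sits, the expected step is a number no higher from compound 1 to compound 4 (the limit leaves the size open), which is none beyond the scatter. For compound 4 the estimate in this assay is 100000 nM, with a range from 50000 nM to 300000 nM, and the result is expected most likely to come back as a limit again.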

Compound 4, half-maximal cytotoxic concentration: > 100000 nM
Compound 4: no number, only a limit; the forecaster's own chance of this, stated with the estimate: 70%; the middle value lies on the limit itself.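

Compound 1 and compound 4 both return only a limit in this assay, so the step from (2-sulfoethyl)amino to hydroxy on a carbonyl carbon cannot be read: the limit of > 100000 nM in this assay, at which 2 of the 4 values shown sit.

The compounds shown leave open whether this exchange shifts the tolerated concentration in this assay at all, as neither compound carries a number there.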